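The compounds below may be only part of what the source reports. "The series", "measured", "known", "first", "only" and "open" are said of these compounds alone.

Working notes on the series. Compound 1 `COc1ccc(-c2ccccc2)c(OC)c1` and compound 3 `COc1ccc(-c2ccccc2)cc1OC` are built from the same atoms joined differently; the difference between the two cores is not broken down here. In an ADME assay on HEK293 cells (Homo sapiens) for cytotoxicity, read by MTT assay, with a stated time of 3 days (on this read-out higher numbers stand for weaker inhibition and lower numbers for stronger inhibition), compound 1 gives 27 ug/mL. In this assay compound 3 gives 26 ug/mL, within the usual scatter of compound 1. Compound 2 `COc1ccc(-c2ccccc2O)c(OC)c1` carries hydroxy in place of hydrogen on an aromatic carbon on the core of compound 1. In this assay compound 2 gives only > 100 ug/mL, which is a limit of the assay and not a number. The step is an at least 3.7-fold higher number from compound 1 to compound 2 (0.56 log units; beyond the scatter); its size is known only as a bound because the limit of > 100 ug/mL in this assay, at which 1 of the 3 values shown sits, caps what the assay reports. Compound 4 `COc1ccc(-c2cccc(O)c2)cc1OC` carries hydroxy in place of hydrogen on an aromatic carbon on the core of compound 3. This is the same kind of change as that made from compound 1 to compound 2, though not the same: the hydroxy enters ortho to a large group in compound 2 and meta to a large group in compound 4. From compound 3, in this assay the step is expected to be a 3.1-fold higher number from compound 3 to compound 4 (0.49 log units; beyond the scatter), resting on an at least 3.7-fold higher number from compound 1 to compound 2 (0.56 log units; beyond the scatter). Compound 4 is therefore estimated at 80 ug/mL, expected between 30 ug/mL and 200 ug/mL.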

Compound 4, half-maximal inhibitory concentration: 23.1 ug/mL
Compound 4: middle estimate off by 3.5-fold (0.54 log units), on the high side; the measured number lies below the stated range.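

In this assay, hydroxy in place of hydrogen on an aromatic carbon gives a 1.1-fold lower number from compound 3 to compound 4 (0.05 log units; within the scatter), so on the core of compound 3 this change shows no effect beyond the scatter, and the result on the core of compound 1 does not carry over: the same change on two cores in this assay, an at least 3.7-fold higher number (0.56 log units; beyond the scatter) from compound 1 to compound 2 and a 1.1-fold lower number (0.05 log units; within the scatter) from compound 3 to compound 4, at least 4.1-fold (0.61 log units) apart, beyond the scatter of two such steps. Going by these compounds, the earlier step is known only as a bound, so the gap between the two steps is also a bound and the full size of the earlier step remains unknown: the limit of > 100 ug/mL in this assay, at which 1 of the 4 values shown sits. These two pairs show that the change cannot be carried from one core to the other in this series, but they do not separate the effect of the core from that of the place where the hydroxy enters, and they give no rule for any other core.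

Still open, on these data alone, is what hydroxy meta to a large group would do on the core of compound 1. Also open, as far as these compounds go, is whether an amine or a carboxylic acid at that place would follow hydroxy on either core.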